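The compounds below may be only part of what the source reports. "The series", "measured", "known", "first", "only" and "open" are said of these compounds alone.

In a functional assay on Hs-578T cells (Homo sapiens) for inhibition, read by sulforhodamine B assay, with a stated time of 48 h, tested at 100 uM (on this read-out lower numbers stand for a stronger effect and higher numbers for a weaker effect at the one concentration tested), three compounds sharing one core have been measured. Compound 1 `COc1cc(Cl)cc(-c2nn(-c3cccc(NC(=O)Nc4ccc(Cl)c(C(F)(F)F)c4)c3)cc2-c2ccncc2)c1` gives -6%, compound 2 `COc1cc(Cl)cc(-c2nn(-c3cccc(NC(=O)Nc4ccc(Cl)c(Cl)c4)c3)cc2-c2ccncc2)c1` gives 28%, and compound 3 `COc1cc(Cl)cc(-c2nn(-c3cccc(NC(=O)Nc4cccc(C(F)(F)F)c4)c3)cc2-c2ccncc2)c1` gives 21%. Compound 3 thus stands second highest of the three: its number lies within the scatter of compound 2, while it is separated from compound 1 by a number 27 percentage points higher from compound 1 to compound 3 (beyond the scatter). Compound 4 `COc1cc(Cl)cc(-c2nn(-c3cccc(NC(=O)c4cccc(C(F)(F)F)c4)c3)cc2-c2ccncc2)c1` differs from compound 3 in one place: 3-(trifluoromethyl)phenyl in place of (3-(trifluoromethyl)phenyl)amino on a carbonyl carbon. Within the data shown here, no measured step covers a change of this kind; the steps seen so far, a number 34 percentage points higher from compound 1 to compound 2 (beyond the scatter) and a number 7 percentage points lower from compound 2 to compound 3 (within the scatter), only exchanged groups on an aromatic carbon. The step of a number 4 percentage points higher from compound 3 to compound 4 (within the scatter) is therefore expected to be uncertain in direction. Compound 4 is expected to give about 25%, somewhere between 0% and 55%.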

Compound 4, a percentage reported as activity, at one concentration (the size of the read-out at that concentration, not a potency): 53%
For compound 4 the middle estimate is 28 percentage points below the measured one; low and high end bracket the measured number.
By their numbers in this assay, from the lowest: compound 1; then compounds 3 and 2 (each within the scatter of the next); then compound 4.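

In this assay, replacing (3-(trifluoromethyl)phenyl)amino with 3-(trifluoromethyl)phenyl on the carbonyl carbon removes a nitrogen and its hydrogen-bond donor and weakens the effect, with a number 32 percentage points higher from compound 3 to compound 4 (beyond the scatter). The comparisons with the other two compounds point the same way, with a number 25 percentage points higher from compound 2 to compound 4 (beyond the scatter) and a number 59 percentage points higher from compound 1 to compound 4 (beyond the scatter), although these steps also change the groups on the aromatic ring. Nothing available explains this loss. From the compounds shown here alone, it remains open whether a methylamino link or an oxygen link in place of that nitrogen would keep the stronger effect.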